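A few compounds are considered here, and "the series" means these few. Any claim that something is new, unique, unknown or untested is made for them only; others in the source may bear on it.

In an ADME assay on microsomes from liver (Mus musculus) for metabolic stability, read by LC-MS, using NADPH, tested at 2 uM (on this read-out lower numbers stand for a shorter-lived compound and higher numbers for a longer-lived compound), compound 1 (`Cc1cc(CC2CCCCC2)n(O)c(=O)c1`) gives < 0.0834 h as a limit of the assay and not as a number. In this assay, among the compounds with values here, compound 2 (`Cc1cc(C2CCCCCC2)n(O)c(=O)c1`) gives 0.133 h as the only measured number so far. Compound 3 (`O=c1cc(-c2ccccc2)cc(CC2CCCCC2)n1O`) has phenyl in place of methyl on an aromatic carbon, opposite the ring nitrogen (phenyl in place of methyl on an aromatic carbon). Within the data shown here, no measured step covers this change, so no step beyond the scatter is expected in this assay in either direction. Compound 2 with 0.133 h is the only anchor, and compound 3 is therefore also expected to be short-lived. A further limit result is quite possible for compound 3. The estimated step (an at least 1.0-fold higher number from compound 1 to compound 3 (0.03 log units; that floor lies within the scatter)) is expected to stay within the usual scatter. For compound 3 the expected half-life is 0.09 h within an estimated range of 0.05 h to 0.3 h in this read-out.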

Compound 3, half-life: < 0.0834 h
Compound 3: only a limit was reported; the forecaster's own chance of this, stated with the estimate: 50%; at least 1.0-fold (0.03 log units) between middle value and limit.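

No step from compound 1 to compound 3 can be read in this assay, since both results are limits of the assay: the limit of < 0.0834 h in this assay, at which 2 of the 3 values shown sit.

Left open is whether phenyl in place of methyl on an aromatic carbon shifts the half-life at all, and in which direction.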